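Replacing an amino group with chloro on a biaryl dichloroacetamide

The source may report more compounds than this note shows. Statements on the series, on what has been measured and on what is new or still open speak of the compounds shown alone.

Of the compounds shown here, three sharing one core have been tested in a functional assay on A549 cells (Homo sapiens) for cytotoxicity, read by MTT assay, with a stated time of 68 h; a higher number here means a weaker inhibitor, a lower number a stronger inhibitor. Compound 1 `O=C(Nc1cccc(-c2cccc(NC(=O)C(Cl)Cl)c2)c1)C(Cl)Cl` gives 47900 nM. Compound 2 `O=C(Nc1cccc(-c2cccc(F)c2)c1)C(Cl)Cl` gives 9530 nM. Compound 3 `Nc1cccc(-c2cccc(NC(=O)C(Cl)Cl)c2)c1` gives 50000 nM, the highest of the three numbers, though its gap to compound 1 is within the scatter, as the step of a 1.0-fold higher number from compound 1 to compound 3 (0.02 log units; within the scatter) shows; only compound 2 sits clearly apart, by a 5.2-fold higher number from compound 2 to compound 3 (0.72 log units; beyond the scatter).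

The new compound 4 `O=C(Nc1cccc(-c2cccc(Cl)c2)c1)C(Cl)Cl` differs from compound 3 in one place: chloro in place of amino on an aromatic carbon. The most telling comparison is the step from compound 2 to compound 3, in which amino replaced fluoro on an aromatic carbon and the number rose by a 5.2-fold higher number from compound 2 to compound 3 (0.72 log units; beyond the scatter). The step of a 5.0-fold lower number from compound 1 to compound 2 (0.70 log units; beyond the scatter) also shows that a small substituent there goes with a lower number than a larger one. The change to compound 4 runs the other way from the step into compound 3, putting a halogen back in place of amino, so a modest drop toward the level of compound 2 is expected rather than no change.

Compound 4 is therefore estimated at 10000 nM, within a range from 3000 nM to 35000 nM, which corresponds to an expected step of a 5.0-fold lower number from compound 3 to compound 4 (0.70 log units; beyond the scatter).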

Compound 4, half-maximal inhibitory concentration: 21400 nM
Beside the measured number, compound 4's estimate is 2.1-fold (0.33 log units) below it, within the range that was stated.
By their numbers in this assay, from the lowest: compound 2; then compound 4; then compounds 1 and 3 (each within the scatter of the next).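

In this assay a halogen at this position does not by itself bring the number to the level of compound 2: the change from amino to chloro gives a 2.3-fold lower number from compound 3 to compound 4 (0.37 log units; beyond the scatter) and no more, and the two halogens stay apart, with a 2.2-fold higher number from compound 2 to compound 4 (0.35 log units; beyond the scatter) on going from fluoro to chloro. Chloro also stands clear of the larger ((dichloromethyl)carbonyl)amino group, with a 2.2-fold lower number from compound 1 to compound 4 (0.35 log units; beyond the scatter) in that step, so these four compounds fall into three levels: fluoro lowest, chloro in the middle, and amino and ((dichloromethyl)carbonyl)amino together at the top, with no order between those two. Chloro and amino each count as one heavy atom, yet their numbers differ, so the count of atoms at this position does not settle the result.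

Nothing available explains why these groups differ. The compounds shown leave open where a methyl, a methoxy or a bromo group at this position would fall, and whether plain hydrogen there would give a number lower than that of compound 2.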